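Three inactive benzyl analogues and a fourth to be tested

This account rests on a few compounds, and the source may have more. Where it says the series, first, only, none or still open, it means among the compounds named here.

Compound 1, `COc1cccc(CNc2ncnc3c2ncn3[C@@H]2O[C@H](CO)[C@@H](O)[C@H]2O)c1OC`: > 166000 nM
Compound 2, `COc1ccc(CNc2ncnc3c2ncn3C2OC(CO)[C@@H](O)[C@H]2O)c(O)c1`: > 166000 nM
Compound 3, `COc1cc(CNc2ncnc3c2ncn3[C@@H]2O[C@H](CO)[C@@H](O)[C@H]2O)cc(OC)c1O`: > 166000 nM

In a functional assay on HOS cells (Homo sapiens) for antiproliferative activity, with a stated time of 72 h (a lower number here means a stronger inhibitor, a higher number a weaker inhibitor), compound 1 reaches only > 166000 nM, which is a limit of the assay and not a measured number. Compound 2 likewise gives > 166000 nM, again a limit. Compound 3 gives > 166000 nM, also a limit. All three values therefore sit at the same ceiling, as the limit of > 166000 nM in this assay, at which 3 of the 3 values shown sit, records, and no ordering among them can be read from the data.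

Compound 4, `Cc1cccc(CNc2ncnc3c2ncn3[C@@H]2O[C@H](CO)[C@@H](O)[C@H]2O)c1O`, has not yet been measured in this assay. It differs from compound 1 in one place: 2-hydroxy-3-methylphenyl in place of 2,3-dimethoxyphenyl on a saturated chain carbon bound to a nitrogen on an aromatic ring. The shared core and the sugar-bearing part are untouched.

For the measured compounds named here, since no pair of measured compounds differs in one place, no measured step is available to gauge this change. Three aryl variants at the limit give no sign that a fourth variation of the same ring will move the read-out. The step that the limit leaves unreadable from compound 1 to compound 4 is therefore expected to be none beyond the scatter, and most probably only another limit. Compound 4 is estimated at 200000 nM, within 90000 nM to 500000 nM.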

Compound 4, half-maximal inhibitory concentration: > 166000 nM
Compound 4: a limit, no number; the forecaster's own chance of this, stated with the estimate: 85%; the middle value does not contradict the limit.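

In this assay compound 4 gives > 166000 nM, which is a limit of the assay and not a number. For the compounds shown here, compound 1 and compound 4 both sit at a limit, so no step between them can be read. The compounds shown leave open which structural change, if any, would bring a measurable value in this assay.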